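Shifting a Bromine on a Shared Core

This account rests on a few compounds, and the source may have more. Where it says the series, first, only, none or still open, it means among the compounds named here.

Two compounds set the scene. Compound 1, `N=C1NC(=O)/C(=C\c2c[nH]c3c(Br)cccc23)N1`, was tested in an assay on CHO cells for displacement of a labelled ligand from 5-hydroxytryptamine receptor 5A (Homo sapiens) (a higher number here means a weaker inhibitor, a lower number a stronger inhibitor), and gives 112 nM. Compound 2, `N=C1NC(=O)/C(=C\c2c[nH]c3ccccc23)N1`, gives 101 nM in this assay. For the measured compounds named here, the one step between them, a 1.1-fold lower number from compound 1 to compound 2 (0.04 log units; within the scatter), replaces bromo with hydrogen on an aromatic carbon and leaves the number essentially where it was. On the two numbers at hand, compound 2 therefore stands at a value indistinguishable from that of compound 1.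

Compound 3, `N=C1NC(=O)/C(=C\c2c[nH]c3cccc(Br)c23)N1`, has not yet been measured. It differs from compound 2 by bromo in place of hydrogen on an aromatic carbon. Going by the values given here, the only measured step that bears on this change is the removal of a bromo from an aromatic carbon of the same core, a 1.1-fold lower number from compound 1 to compound 2 (0.04 log units; within the scatter), which stayed inside the scatter. Putting a bromo back on another aromatic carbon of that ring is therefore expected to give no step beyond the scatter in this assay, in either direction: a 1.1-fold higher number from compound 2 to compound 3 (0.04 log units; within the scatter). Compound 3 is accordingly estimated at 110 nM, with a range from 50 nM to 250 nM.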

Compound 3, inhibition constant: 123 nM
Estimate against measurement, compound 3: 1.1-fold (0.05 log units) below, and the stated range covers the measured number.
By their numbers in this assay, from the lowest: compounds 2, 1 and 3 (each within the scatter of the next).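

In this assay, the step of a 1.2-fold higher number from compound 2 to compound 3 (0.09 log units; within the scatter) shows that bromo can take the place of hydrogen on this aromatic carbon, ortho to a fused ring and meta to a fused ring, without the number moving beyond the scatter. Until now, only one bromo site on the shared core had been read. Taken with the step of a 1.1-fold lower number from compound 1 to compound 2 (0.04 log units; within the scatter), this result shows that hydrogen and bromo cannot be told apart in this assay at either of two aromatic carbons of that ring, so among these three compounds the place of the bromo has no resolved effect on the number. No measurement at hand accounts for this absence of a change.

As far as these compounds go, what remains open is whether this insensitivity extends beyond bromo, since all three compounds carry either bromo or hydrogen on that ring. An amine, a carboxylic acid or a longer chain such as n-butyl on the same aromatic carbon could still move the number beyond the scatter, in either direction, and the compounds shown give no reading of any of these groups.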